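The source may hold more compounds than are shown below. What is called first, only, known or untested is meant among the compounds shown, and "the series" means these compounds.

Measured so far in a functional assay on PC-3 cells (Homo sapiens) for inhibition, read by MTT assay, with a stated time of 48 h; on this read-out lower numbers stand for stronger inhibition and higher numbers for weaker inhibition:
- compound 1 `COc1ccc(C(=O)CSc2nnc(-c3cc(OC)c(OC)c(OC)c3)n2-c2ccc(OC)cc2)cc1`: > 60000 nM (a limit, not a number)
- compound 2 `COc1ccc(-n2c(SCC(=O)C3CC3)nnc2-c2cc(OC)c(OC)c(OC)c2)cc1`: 37200 nM

Among the compounds with values here, compound 2, at 37200 nM, holds the only number in the set. For compound 1 the result is the limit of > 60000 nM in this assay, at which 1 of the 2 values shown sits, and it is a limit.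

Next in line is compound 3 `CCOC(=O)CSc1nnc(-c2cc(OC)c(OC)c(OC)c2)n1-c1ccc(OC)cc1`, with ethoxy in place of cyclopropyl on a carbonyl carbon. Read one bond further out, this is cyclopropylcarbonyl to ethoxycarbonyl, and the rest of the structure stays the same.

Within the data shown here, only one measured step bears on this change, since it falls on the same carbonyl carbon: an at least 1.6-fold lower number from compound 1 to compound 2 (0.20 log units; that floor lies within the scatter). That is a replacement of 4-methoxyphenyl by cyclopropyl, so it is a guide to the place and not to ethoxy itself. Among the measured compounds shown here, with only this step to go on, no change beyond the scatter is expected in this assay, and no direction is favoured. The estimated outcome is a 1.1-fold higher number from compound 2 to compound 3 (0.03 log units; within the scatter). A result reported only as a limit, as with compound 1, remains possible.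

For compound 3 the expected value is 40000 nM, with an estimated range of 16000 nM to 90000 nM.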

Compound 3, half-maximal inhibitory concentration: > 60000 nM
Compound 3 gave a limit, no number; the forecaster's own chance of this, stated with the estimate: 35%; middle value at least 1.5-fold (0.17 log units) away from the limit.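

In this assay compound 3 gives > 60000 nM, which is a limit and not a number. The step with ethoxy in place of cyclopropyl on the carbonyl carbon is an at least 1.6-fold higher number from compound 2 to compound 3 (0.20 log units; that floor lies within the scatter), so cyclopropyl remains the only group at this place with a measured number, but its edge over ethoxy is not shown to exceed the scatter. Compound 1 and compound 3 cannot be ordered, and the step between them cannot be read, because both stand at the same limit: the limit of > 60000 nM in this assay, at which 2 of the 3 values shown sit.

Still open, going by these compounds, is how far compound 1 and compound 3 lie past that limit, and so whether ethoxy and 4-methoxyphenyl differ at all at this place. Also open, on these data alone, is whether a carboxylic acid, an amide built from a simple amine, or a longer chain on the carbonyl carbon would give a number, and how such a number would compare with compound 2 at 37200 nM.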